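Aryl swap on the shared core: expected effect in compound 4

The source may report more compounds than this note shows. Statements on the series, on what has been measured and on what is new or still open speak of the compounds shown alone.

Compound 2 `CCCCCCCCc1ccc(OCC(=O)Cn2nnc(-c3ccc(C(=O)OC)cc3)n2)cc1` gives 29 nM in an assay on microsomes from brain for inhibition of Fatty-acid amide hydrolase 1 (Rattus norvegicus), read by fluorescence and HPLC, with a stated time of 60 min (a higher number here means a weaker inhibitor, a lower number a stronger inhibitor), the second highest of three numbers; its nearest neighbour is compound 1 `CCCCCCCCc1ccc(OCC(=O)Cn2nnc(C)n2)cc1` at 27 nM, its furthest compound 3 `CCCCCCCCc1ccc(OCC(=O)Cn2nnc(C(=O)O)n2)cc1` at 41 nM, and all three lie within the scatter of one another. Compound 4 `CCCCCCCCc1ccc(OCC(=O)Cn2nnc(-c3cccc(C(=O)O)c3)n2)cc1` carries 3-carboxyphenyl in place of 4-(methoxycarbonyl)phenyl on an aromatic carbon. Within the data shown here, the steps that bear on this position are a 1.1-fold higher number from compound 1 to compound 2 (0.03 log units; within the scatter), a 1.5-fold higher number from compound 1 to compound 3 (0.18 log units; within the scatter) and a 1.4-fold higher number from compound 2 to compound 3 (0.15 log units; within the scatter): methyl, 4-(methoxycarbonyl)phenyl and carboxy at this aromatic carbon all give numbers within the scatter in this assay, so a 3-carboxyphenyl there is expected to change little. Compound 4 is therefore estimated at 33 nM with a range of 15 nM to 75 nM, an expected step of a 1.1-fold higher number from compound 2 to compound 4 (0.06 log units; within the scatter).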

Compound 4, half-maximal inhibitory concentration: 36 nM
Beside the measured number, compound 4's estimate is 1.1-fold (0.04 log units) below it; the range from low to high includes it.
By their numbers in this assay, from the lowest: compounds 1, 2, 4 and 3 (each within the scatter of the next).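

The 3-carboxyphenyl group adds an aryl group bearing a free carboxy at this aromatic carbon, and in this assay it stays within the scatter of all three earlier groups (a 1.2-fold higher number from compound 2 to compound 4 (0.09 log units; within the scatter); a 1.1-fold lower number from compound 3 to compound 4 (0.06 log units; within the scatter); a 1.3-fold higher number from compound 1 to compound 4 (0.12 log units; within the scatter)). Adding the aryl group to a carboxy, or exchanging the ester-bearing aryl group for this one, therefore does not separate these compounds. No measurement here accounts for this flat response.

Still open, on these data alone, is whether a 4-carboxyphenyl or 3-aminophenyl group at this carbon would also stay within the scatter.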